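A few compounds are considered here, and "the series" means these few. Any claim that something is new, unique, unknown or untested is made for them only; others in the source may bear on it.

Measured so far in a functional assay, with a stated time of 150 min; a lower number here means a stronger inhibitor, a higher number a weaker inhibitor:
Compound 1 `COc1ccc(-c2nc(SC)n(C)c(=O)c2C#N)cc1`, where compound 1 gives 73 ug/mL.
Compound 2 `COc1ccc(-c2nc(NN)n(C)c(=O)c2C#N)cc1`, where compound 2 gives 56 ug/mL.
Compound 3 `CCOC(=O)c1cnn(-c2nc(-c3ccccc3Cl)c(C#N)c(=O)n2C)c1N`, where compound 3 gives 93 ug/mL.

Compound 1 stands second highest of the three numbers; its gaps to compound 2 and to compound 3 both lie within the scatter, so the three are not separated. Within the data shown here, the only single-point step in the set, a 1.3-fold lower number from compound 1 to compound 2 (0.12 log units; within the scatter), concerns a different part of the shared core and is itself within the scatter. Compound 4 `CSc1nc(-c2ccc(N(C)C)cc2)c(C#N)c(=O)n1C` differs from compound 1 by dimethylamino in place of methoxy on an aromatic carbon. Among the measured compounds shown here, no measured step touches this position, so no change beyond the scatter is expected. On this basis the expected step is a 1.0-fold lower number from compound 1 to compound 4 (0.02 log units; within the scatter). Compound 4 is estimated at 70 ug/mL, with a range from 30 ug/mL to 160 ug/mL.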

Compound 4, half-maximal inhibitory concentration: 93 ug/mL
Estimate against measurement, compound 4: 1.3-fold (0.12 log units) below; the range from low to high includes it.
By their numbers in this assay, from the lowest: compounds 2, 1, 3 and 4 (each within the scatter of the next).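

In this assay, dimethylamino in place of methoxy gives a 1.3-fold higher number from compound 1 to compound 4 (0.11 log units; within the scatter), the first step read at this aromatic carbon, para to a large group. At this position, the two groups are therefore not separated, and this step adds no change beyond the scatter to the one read elsewhere on the shared core. No supporting evidence bears on this step.

From the compounds shown here alone, whether a carboxylic acid, a primary amine or a longer alkoxy chain here would give a step beyond the scatter stays open. So does whether this step would hold with aminoamino in place of methylsulfanyl.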